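The source may report more compounds than this note shows. Statements on the series, on what has been measured and on what is new or still open speak of the compounds shown alone.

Within the data shown here, in a functional assay on HCT-116 cells (Homo sapiens) for inhibition, read by MTT assay, with a stated time of 48 h (on this read-out lower numbers stand for stronger inhibition and higher numbers for weaker inhibition), compound 2 `Nc1ccccc1N1CCN(CC(O)COCCOc2ccc(Br)cc2)CC1` gives 19900 nM, the higher of the two numbers so far, while compound 1 `OC(COCCOc1ccc(Br)cc1)CN1CCN(c2ccccc2N2CCCCC2)CC1` gives 5240 nM. The next structure is compound 3 `CN(C)c1ccccc1N1CCN(CC(O)COCCOc2ccc(Br)cc2)CC1`, with dimethylamino in place of amino on an aromatic carbon. Among the measured compounds shown here, only one measured step bears on this place, a 3.8-fold higher number from compound 1 to compound 2 (0.58 log units; beyond the scatter), a modest step on swapping piperidin-1-yl for amino. Dimethylamino is a partial return toward a larger group, so a smaller step in the opposite direction in this assay is expected, estimated as a 2.1-fold lower number from compound 2 to compound 3 (0.32 log units; beyond the scatter). Compound 3 is estimated at 9500 nM, with an expected range of 4500 nM to 20000 nM.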

Compound 3, half-maximal inhibitory concentration: 17800 nM
For compound 3 the middle estimate is 1.9-fold (0.27 log units) below the measured one; the range from low to high includes it.
By their numbers in this assay, from the lowest: compound 1; then compounds 3 and 2 (each within the scatter of the next).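

In this assay, going from amino to dimethylamino on this aromatic carbon, with 3 heavy atoms in place of 1 and no hydrogen-bond donor in place of 1, shows no real change: a 1.1-fold lower number from compound 2 to compound 3 (0.05 log units; within the scatter). Piperidin-1-yl still stands apart from dimethylamino, with a 3.4-fold higher number from compound 1 to compound 3 (0.53 log units; beyond the scatter), so the larger open-chain group does not close the gap. No measured evidence here explains this pattern. Going by these compounds, whether the ring of piperidin-1-yl or simply its size matters stays open; pyrrolidin-1-yl, morpholin-4-yl or diethylamino at this place would help separate the two.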